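A few compounds are considered here, and "the series" means these few. Any claim that something is new, unique, unknown or untested is made for them only; others in the source may bear on it.

Of the compounds shown here, three built on a shared core have been measured in a functional assay on K562 cells (Homo sapiens) for cytotoxicity; a higher number here means a weaker inhibitor of growth, a lower number a stronger inhibitor of growth. Compound 1 `OCCCCC#Cc1ccccc1C#Cc1ccccc1` gives 21100 nM. Compound 2 `OCCCCC#Cc1ccccc1C#Cc1cccc(O)c1` gives 19200 nM, and compound 3 `OCCCCC#Cc1ccccc1C#Cc1ccc(O)cc1` gives 20400 nM. Compound 3 sits among the three with compound 1 nearest and compound 2 furthest, and every step between them lies within the scatter: a 1.1-fold lower number from compound 1 to compound 2 (0.04 log units; within the scatter), a 1.0-fold lower number from compound 1 to compound 3 (0.01 log units; within the scatter) and a 1.1-fold higher number from compound 2 to compound 3 (0.03 log units; within the scatter).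

Compound 4 `OCCCCC#Cc1ccccc1C#Cc1ccc(C(F)(F)F)cc1` differs from compound 3 in one place: trifluoromethyl in place of hydroxy on an aromatic carbon. The measured steps that bear on this change are a 1.0-fold lower number from compound 1 to compound 3 (0.01 log units; within the scatter), where hydroxy entered in place of hydrogen on an aromatic carbon, and a 1.1-fold higher number from compound 2 to compound 3 (0.03 log units; within the scatter), where the hydroxyphenyl group was moved; both were within the scatter. Going by the values given here, no measured step brings in trifluoromethyl, so the guidance is only indirect. Since altering this aromatic carbon has so far left this assay unmoved, compound 4 is expected to show a step no larger than the scatter, a 1.0-fold lower number from compound 3 to compound 4 (0.01 log units; within the scatter). Compound 4 is therefore estimated at 20000 nM, within a range from 8000 nM to 50000 nM.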

Compound 4, concentration for 50% growth inhibition: 18200 nM
Estimate against measurement, compound 4: 1.1-fold (0.04 log units) above, within the range that was stated.
By their numbers in this assay, from the lowest: compounds 4, 2, 3 and 1 (each within the scatter of the next).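

Until now this aromatic carbon, para to a large group, had carried only hydrogen or hydroxy. Trifluoromethyl brings more heavy atoms and removes the hydrogen-bond donor and acceptor of hydroxy, yet this assay shows a 1.1-fold lower number from compound 3 to compound 4 (0.05 log units; within the scatter) and, against plain hydrogen, a 1.2-fold lower number from compound 1 to compound 4 (0.06 log units; within the scatter). Both steps lie within the scatter, so this position now accepts a larger group without hydrogen-bonding atoms and with no measurable shift in growth inhibition, though no measurement here explains that flatness.

Still open, going by these compounds, is whether any group at this carbon can move the number, for instance an amine or a carboxylic acid. Also open, on these data alone, is whether a change elsewhere on the shared core, such as a longer chain, would do so.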